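Swapping a benzyl arm for isopropyl on the amine

The source may report more compounds than this note shows. Statements on the series, on what has been measured and on what is new or still open speak of the compounds shown alone.

Of the compounds shown here, three sharing one core have been measured in a functional assay on DLD-1 cells (Homo sapiens) for inhibition, read by MTT assay, with a stated time of 72 h; on this read-out higher numbers stand for weaker inhibition and lower numbers for stronger inhibition. Compound 1 `COc1ccc(CNCc2c(OC)cc(Oc3cccc(Nc4ccccc4)c3)cc2OC)cc1` gives 1910 nM, compound 2 `CNCc1c(OC)cc(Oc2cccc(Nc3ccccc3)c2)cc1OC` gives 11900 nM, and compound 3 `COc1cc(Oc2cccc(Nc3ccccc3)c2)cc(OC)c1CNCc1ccc(C)cc1` gives 6080 nM. Among these three numbers compound 3 stands second highest, separated from compound 2 by a gap that lies within the scatter, and from compound 1 by a 3.2-fold higher number from compound 1 to compound 3 (0.50 log units; beyond the scatter), a gap beyond it. The unmeasured compound 4 `COc1cc(Oc2cccc(Nc3ccccc3)c2)cc(OC)c1CNC(C)C` differs from compound 3 in one place: isopropyl in place of 4-methylbenzyl on an amine nitrogen.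

Two measured steps speak to this change. Removing the whole 4-methoxyphenyl piece gave a 6.2-fold higher number from compound 1 to compound 2 (0.79 log units; beyond the scatter), while adding 4-methylphenyl to the bare amine gave a 2.0-fold lower number from compound 2 to compound 3 (0.29 log units; within the scatter), a shift within the scatter. Compound 4 keeps a carbon group on the amine but loses the ring that compound 3 carries, so in this assay a shift no larger than modest is expected, most likely a somewhat higher number. The estimate for compound 4 is therefore 8500 nM, with a range from 4000 nM to 18000 nM, meaning an expected step of a 1.4-fold higher number from compound 3 to compound 4 (0.15 log units; within the scatter).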

Compound 4, half-maximal inhibitory concentration: > 20000 nM
Compound 4: a limit, no number; the forecaster's own chance of this, stated with the estimate: 3%; middle value at least 2.3-fold (0.37 log units) away from the limit.
By their numbers in this assay, from the lowest: compound 1; then compounds 3 and 2 (each within the scatter of the next). At a limit, above all of these: compound 4.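

In this assay compound 4 stands at > 20000 nM, which is a limit of the assay and not a number. On the amine nitrogen, isopropyl proves a poor stand-in for the benzyl arms, with an at least 3.2-fold higher number from compound 3 to compound 4 (0.51 log units; beyond the scatter) against 4-methylbenzyl and an at least 10-fold higher number from compound 1 to compound 4 (1.01 log units; beyond the scatter) against 4-methoxybenzyl, so keeping a small carbon group there does not keep the read-out of either ring-bearing compound. The picture is not a simple trend with the size of the group, however: compound 2, with only methyl on that nitrogen, lies within the scatter of compound 3, and an at least 1.6-fold higher number from compound 2 to compound 4 (0.22 log units; that floor lies within the scatter) leaves open any firm order between methyl and isopropyl.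

As far as these compounds go, the true value of compound 4 remains unknown, and with it the full size of all three steps. Also open, from the compounds shown here alone, is whether the ring itself or simply the length of the arm carries the difference, which a cyclohexylmethyl group or a longer chain such as n-butyl on the same nitrogen could begin to separate.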